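Aryl Substituents on the Carbonyl of the Shared Core

The compounds below may be only part of what the source reports. "The series", "measured", "known", "first", "only" and "open" are said of these compounds alone.

Of the compounds shown here, three have been measured in an assay on LtK cells with ATP-sensitive inward rectifier potassium channel 11 (Homo sapiens) as the target; on this read-out higher numbers stand for an effect only at larger amounts of compound and lower numbers for an effect already at smaller amounts. Compound 1 `CC(C)C(=O)Nc1c(C(O)(C(F)(F)F)C(F)(F)F)ccc2ccccc12` gives 6630 nM, compound 2 `O=C(Nc1c(C(O)(C(F)(F)F)C(F)(F)F)ccc2ccccc12)C1CC1` gives 751 nM, and compound 3 `O=C(Nc1ccc(Cl)cc1)Nc1c(C(O)(C(F)(F)F)C(F)(F)F)ccc2ccccc12` gives 276 nM. Compound 3 stands lowest of the three: the step of a 2.7-fold lower number from compound 2 to compound 3 (0.43 log units; beyond the scatter) is modest, the step of a 24-fold lower number from compound 1 to compound 3 (1.38 log units; beyond the scatter) is large, and the step of an 8.8-fold lower number from compound 1 to compound 2 (0.95 log units; beyond the scatter) lies in between. All three changes sit on the same carbonyl carbon.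

Compound 4 `Cc1ccc(C(=O)Nc2c(C(O)(C(F)(F)F)C(F)(F)F)ccc3ccccc23)cc1` differs from compound 3 in one place: 4-methylphenyl in place of (4-chlorophenyl)amino on a carbonyl carbon. Going by the values given here, the steps that bear on this are those at the same carbonyl carbon, where the aromatic group of compound 3 gave the lowest number in this assay, as the step of a 24-fold lower number from compound 1 to compound 3 (1.38 log units; beyond the scatter) shows. Compound 4 keeps a six-membered aromatic ring but loses the hydrogen-bond donor. The expected step of a 1.8-fold higher number from compound 3 to compound 4 (0.26 log units; within the scatter) is therefore small, probably toward a somewhat higher number, near the scatter. For compound 4 the estimated value in this assay is 500 nM, with a range from 150 nM to 1600 nM.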

Compound 4, half-maximal effective concentration: 76 nM
Beside the measured number, compound 4's estimate is 6.6-fold (0.82 log units) above it, and the stated range ends above it.
By their numbers in this assay, from the lowest: compound 4; then compound 3; then compound 2; then compound 1.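

At this carbonyl carbon, a low number in this assay does not require the hydrogen-bond donor of the (4-chlorophenyl)amino group: the change to 4-methylphenyl gives a 3.6-fold lower number from compound 3 to compound 4 (0.56 log units; beyond the scatter) as the outcome. Against the two non-aromatic groups the gain is also wider than compound 3 showed, with a 9.9-fold lower number from compound 2 to compound 4 (0.99 log units; beyond the scatter) for cyclopropyl and an 87-fold lower number from compound 1 to compound 4 (1.94 log units; beyond the scatter) for isopropyl, which leaves compound 4 lowest of the four. No measurement is at hand to explain this result.

The change removes the nitrogen and exchanges chlorine for methyl in one step, so the compounds shown leave open which of the two goes with the lower number; 4-chlorophenyl on the same carbonyl carbon would separate them. Also open, from the compounds shown here alone, is whether the aromatic ring itself matters, which cyclohexyl at this place would test.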